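This account rests on a few compounds, and the source may have more. Where it says the series, first, only, none or still open, it means among the compounds named here.

Of the compounds shown here, two sharing one core have been measured so far. In a functional assay on SW-620 cells (Homo sapiens) for cytotoxicity, read by MTT assay, with a stated time of 72 h (a lower number here means a stronger inhibitor, a higher number a weaker inhibitor), compound 1 (`COc1cccc(/C=C2\CCC/C(=C\c3ccc(Cl)cc3)C2=O)c1OC`) gives 11100 nM and compound 2 (`COc1cccc(/C=C2\CCC/C(=C\c3ccccc3Br)C2=O)c1OC`) gives 12100 nM. These two values lie within the scatter of each other, so neither compound can be ranked above the other, and both are measured in the same range.

The next structure, compound 3 (`COc1cccc(/C=C2\CCC/C(=C\c3cccc(OC)c3OC)C2=O)c1`), carries 3-methoxyphenyl in place of the 2-bromophenyl of compound 2, on a double-bonded chain carbon bound to a double-bonded ring carbon: 3-methoxyphenyl in place of 2-bromophenyl on a double-bonded chain carbon bound to a double-bonded ring carbon.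

For the measured compounds named here, only one measured step bears on this change. At the same place, the exchange of 4-chlorophenyl for 2-bromophenyl gave a 1.1-fold higher number from compound 1 to compound 2 (0.04 log units; within the scatter), so that place has so far shown no sensitivity beyond the scatter. Going by the values given here, that is thin evidence, since no measured compound has a methoxy-bearing group there in place of a halogen-bearing one.

The expected change is therefore small, with no clear direction: a 1.2-fold lower number from compound 2 to compound 3 (0.06 log units; within the scatter), an estimate that stays within the scatter. The estimated value for compound 3 is 10500 nM, with an expected range from 4500 nM to 24000 nM.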

Compound 3, half-maximal inhibitory concentration: 7000 nM
Estimate against measurement, compound 3: 1.5-fold (0.18 log units) above; the measured number falls inside the stated range.
By their numbers in this assay, from the lowest: compounds 3, 1 and 2 (each within the scatter of the next).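

In this assay, a methoxy-bearing group now stands at this place instead of a halogen-bearing one, and the numbers stay together: a 1.7-fold lower number from compound 2 to compound 3 (0.24 log units; within the scatter) and a 1.6-fold lower number from compound 1 to compound 3 (0.20 log units; within the scatter). For the compounds shown here, the earlier pair showed only that one halogen-bearing ring could replace another, whereas this result extends that to a different kind of substituent, since 2-bromophenyl counts 0 hydrogen-bond acceptors and 3-methoxyphenyl counts 1, yet the values of all three compounds remain within the scatter of each other. No measurement at hand accounts for this lack of separation, so it can only be recorded as an observation.

The three groups shown at this place are all substituted phenyl rings, so it remains open whether any change on a double-bonded chain carbon bound to a double-bonded ring carbon can move the number beyond the scatter. A phenyl ring carrying an amine or a carboxylic acid, or a longer chain in place of the ring, would test this more severely than another halogen or methoxy group.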